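Chloro to dibromo on the hydroxyphenyl group

The source may hold more compounds than are shown below. What is called first, only, known or untested is meant among the compounds shown, and "the series" means these compounds.

Measured in a functional assay on SMMC-7721 cells (Homo sapiens) for antiproliferative activity, read by MTT assay, with a stated time of 72 h; a higher number here means a weaker inhibitor, a lower number a stronger inhibitor:
- compound 1 `COc1ccc(/C=N/NC(=O)c2cccc(S(=O)(=O)N3CCOCC3)c2)c(O)c1` gives 3950 nM
- compound 2 `CCOc1cccc(/C=N/NC(=O)c2cccc(S(=O)(=O)N3CCOCC3)c2)c1O` gives 6990 nM
- compound 3 `O=C(N/N=C/c1cc(Cl)ccc1O)c1cccc(S(=O)(=O)N2CCOCC2)c1` gives 6820 nM

The three compounds lie close together, and compound 3 sits within the scatter of both others: a 1.7-fold higher number from compound 1 to compound 3 (0.24 log units; within the scatter), and a 1.0-fold lower number from compound 2 to compound 3 (0.01 log units; within the scatter). The next compound, compound 4 `O=C(N/N=C/c1cc(Br)cc(Br)c1O)c1cccc(S(=O)(=O)N2CCOCC2)c1`, has not yet been measured. It differs from compound 3 as follows: 3,5-dibromo-2-hydroxyphenyl in place of 5-chloro-2-hydroxyphenyl on a carbon with a double bond to nitrogen. In words, it carries 3,5-dibromo-2-hydroxyphenyl in place of 5-chloro-2-hydroxyphenyl on a carbon with a double bond to nitrogen.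

Going by the values given here, all the measured steps change the group at this same place: besides the two above, there is a 1.8-fold higher number from compound 1 to compound 2 (0.25 log units; within the scatter). Each of them stays within the scatter. Among the compounds with values here, none of the measured compounds carries bromine, so these steps are only indirect guides. On their evidence, no step beyond the scatter is expected in this assay. The expected step is a 1.4-fold lower number from compound 3 to compound 4 (0.13 log units; within the scatter). The estimated value for compound 4 is 5000 nM, with an expected range from 2000 nM to 12000 nM.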

Compound 4, half-maximal inhibitory concentration: 7310 nM
The estimate for compound 4 lay 1.5-fold (0.16 log units) below the measured number, and the stated range covers the measured number.
By their numbers in this assay, from the lowest: compounds 1, 3, 2 and 4 (each within the scatter of the next).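

Bromine appears here for the first time, and the group on the carbon with a double bond to nitrogen goes from one halogen atom to two, yet the result is a 1.1-fold higher number from compound 3 to compound 4 (0.03 log units; within the scatter). The other steps read alike, a 1.0-fold higher number from compound 2 to compound 4 (0.02 log units; within the scatter) and a 1.9-fold higher number from compound 1 to compound 4 (0.27 log units; within the scatter), so in this assay the four hydroxyphenyl groups shown at this place cannot be told apart, whether they carry halogens or an ether chain. Nothing available bears on why these numbers stay so close.

As far as these compounds go, all four compounds keep the hydroxyl on this phenyl group, so it remains open whether an amine or a carboxylic acid in its place would stay within the same narrow band. The shared core is also constant throughout, which leaves the contribution of its other parts open.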